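Ethoxycarbonyl in place of nitro: an expected cytotoxicity shift

This account rests on a few compounds, and the source may have more. Where it says the series, first, only, none or still open, it means among the compounds named here.

Compound 1 `Cc1ccc(C(C)C)c(OCc2nnc(SCC(=O)Nc3ccc(Br)cc3)n2Cc2ccccc2)c1` and compound 2 `Cc1ccc(C(C)C)c(OCc2nnc(SCC(=O)Nc3ccc([N+](=O)[O-])cc3)n2Cc2ccccc2)c1` share one core and differ only in the group on the outer aromatic ring. In a toxicity assay on MT4 cells (Homo sapiens) for cytotoxicity, read by MTT assay, with a stated time of 5 days (on this read-out higher numbers stand for lower toxicity in this test and lower numbers for higher toxicity in this test), compound 1 gives 66.7 ug/mL, and compound 2 gives 11.2 ug/mL, a change of a 6.0-fold lower number from compound 1 to compound 2 (0.77 log units; beyond the scatter). Among the measured compounds shown here, of the two numbers known, compound 2 holds the lower one. Compound 3 `CCOC(=O)c1ccc(NC(=O)CSc2nnc(COc3cc(C)ccc3C(C)C)n2Cc2ccccc2)cc1` changes that same position once more: ethoxycarbonyl in place of nitro on an aromatic carbon. For the measured compounds named here, no measured step covers this exact exchange; the only step known, from compound 1 to compound 2, shows that swapping the group at this position can move the number beyond the scatter, and the non-nitro partner there gave the higher number. Compound 3 is therefore expected to give about 30 ug/mL, within 10 ug/mL to 90 ug/mL. That estimate corresponds to a step of a 2.7-fold higher number from compound 2 to compound 3 (0.43 log units; beyond the scatter) in this assay.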

Compound 3, half-maximal cytotoxic concentration: 19.8 ug/mL
Estimate against measurement, compound 3: 1.5-fold (0.18 log units) above; the measured number falls inside the stated range.
By their numbers in this assay, from the lowest: compounds 2 and 3 (each within the scatter of the next); then compound 1.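

In this assay, among the compounds shown here, ethoxycarbonyl in place of nitro gives a 1.8-fold higher number from compound 2 to compound 3 (0.25 log units; within the scatter) and so, unlike the one earlier step, this exchange at the position does not move the number beyond the scatter. Ethoxycarbonyl in place of bromo gives a 3.4-fold lower number from compound 1 to compound 3 (0.53 log units; beyond the scatter) and, together with the earlier step, this sets compound 1 apart from both other compounds, making it the least toxic of the three in this test, whereas the earlier pair alone could not show whether a second non-nitro group would also give a high number. Nothing available explains this difference between bromo and the other two groups.

As far as these compounds go, how a chlorine atom, an amine or a carboxylic acid at this position would compare remains open. Also open, from the compounds shown here alone, is whether the same ranking of these three groups would hold on a different core.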